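Naphthalen-1-yl on the sulfur: working notes on the series

The compounds below may be only part of what the source reports. "The series", "measured", "known", "first", "only" and "open" are said of these compounds alone.

- compound 1 `Cc1cc(C)cc(SCc2ccc(/C=C/C(=O)Nc3ccccc3N)cc2)c1` gives 46.1%
- compound 2 `CCc1ccc(SCc2ccc(/C=C/C(=O)Nc3ccccc3N)cc2)cc1` gives 60.7%
- compound 3 `Cc1ccc(SCc2ccc(/C=C/C(=O)Nc3ccccc3N)cc2)cc1` gives 43.4%

In a functional assay on A549 cells (Homo sapiens) for inhibition, read by CCK-8 assay, with a stated time of 72 h, tested at 2 uM (a higher number here means more inhibition of growth at the concentration tested, a lower number less inhibition of growth), compound 3 gives 43.4% and stands level with compound 1 within the scatter, while compound 2 lies clearly higher than both. The gap is a number 17.3 percentage points lower from compound 2 to compound 3 (beyond the scatter) in this set.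

The next compound is compound 4 `Nc1ccccc1NC(=O)/C=C/c1ccc(CSc2cccc3ccccc23)cc1` with the change naphthalen-1-yl in place of 4-methylphenyl on a sulfur on the same sulfur. All three measured steps bear on it, since each exchanges the group on that sulfur. They do not point one way. One gain appears as a number 14.6 percentage points higher from compound 1 to compound 2 (beyond the scatter) but the other exchange gives a number 2.7 percentage points lower from compound 1 to compound 3 (within the scatter) and so shows no separable change. Going by the values given here, no measured compound carries naphthalen-1-yl, so these steps guide the size of the change only loosely. A modest rise is the more likely direction, though a fall cannot be ruled out.

Expected in this assay is a number 6.6 percentage points higher from compound 3 to compound 4 (within the scatter) and this estimate does not amount to a clear step beyond the scatter. For compound 4 the estimated value is 50% with an expected range (33% to 68%).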

Compound 4, percent growth inhibition at one concentration: 59.3%
Estimate against measurement, compound 4: 9.3 percentage points below; measured number inside the range.
By their numbers in this assay, from the lowest: compounds 3 and 1 (each within the scatter of the next); then compounds 4 and 2 (each within the scatter of the next).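

In this assay, naphthalen-1-yl on the sulfur gives a number 15.9 percentage points higher from compound 3 to compound 4 (beyond the scatter) and also a number 13.2 percentage points higher from compound 1 to compound 4 (beyond the scatter), so a group with 2 six-membered aromatic rings is tolerated here and lifts the number over both methyl-bearing phenyl groups. Against 4-ethylphenyl the exchange gives a number 1.4 percentage points lower from compound 2 to compound 4 (within the scatter), which shows that the higher level seen so far is not tied to 4-ethylphenyl alone: two different groups on this sulfur now reach it, while 4-methylphenyl and 3,5-dimethylphenyl stay lower. Nothing at hand explains why these groups sort as they do.

The compounds shown leave open whether the higher level holds for naphthalen-2-yl, for a longer chain such as 4-propylphenyl, or for a phenyl carrying an amine or a carboxylic acid, and so whether it can be exceeded at this position. From the compounds shown here alone, the comparison also rests on growth inhibition at a single concentration in one cell line, so how compound 2 and compound 4 would compare across a range of concentrations remains open.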